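The compounds below may be only part of what the source reports. "The series", "measured", "known", "first", "only" and "open" are said of these compounds alone.

Of the compounds shown here, two from this study have been measured in a functional assay on L1210 cells (Mus musculus) for inhibition; a higher number here means a weaker inhibitor, a lower number a stronger inhibitor. Compound 1, `CCCOC(=O)Nc1nc2cc(C(=O)OCCC)ccc2[nH]1`, carries a propyl carbamate and a propyl ester on the shared core; in this assay compound 1 gives 8200 nM. Compound 2, `COC(=O)Nc1nc2cc(C(=O)NCC(C)(C)C)ccc2[nH]1`, carries a methyl carbamate and a neopentyl amide; in this assay compound 2 gives 8600 nM. The gap between these two numbers falls within the usual scatter of repeated measurements, so compound 2 cannot be told apart from compound 1 on potency, and nothing in this pair points to a trend.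

Compound 3, `COC(=O)Nc1nc2cc(C(=O)OCC3CC3)ccc2[nH]1`, is not yet measured. It differs from compound 2 in one place: cyclopropylmethoxy in place of neopentylamino on a carbonyl carbon. An amide thus gives way to an ester, while the methyl carbamate stays. Within the data shown here, no measured pair shows this exchange, so its effect has to be guessed. Compound 1 also carries an ester rather than an amide and gives 8200 nM, which offers no sign that an ester alone moves the number far. The expected step is small, a 1.1-fold lower number from compound 2 to compound 3 (0.03 log units; within the scatter), with no clear direction beyond the scatter. Compound 3 is estimated at 8000 nM, with a likely range from 2500 nM to 25000 nM.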

Compound 3, half-maximal inhibitory concentration: 6900 nM
For compound 3 the middle estimate is 1.2-fold (0.06 log units) above the measured one; measured number inside the range.
By their numbers in this assay, from the lowest: compounds 3, 1 and 2 (each within the scatter of the next).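

Among these compounds, this is the first measured exchange at this position. In this assay, putting cyclopropylmethoxy in place of neopentylamino on a carbonyl carbon gives a 1.2-fold lower number from compound 2 to compound 3 (0.10 log units; within the scatter), so compound 3 cannot be told apart from compound 2. The exchange turns an amide into an ester, removes the hydrogen-bond donor of neopentylamino, and brings in a three-membered ring, yet together these changes produce no step beyond the scatter, and no measurement here bears on why the number holds.

Because the side chain and the amide-to-ester exchange changed together, this single pair cannot show what each does alone, and they could have effects that cancel or that are both small; a neopentyl ester or a cyclopropylmethyl amide would separate them. Going by these compounds, it also remains open whether a quite different group on this carbonyl carbon, such as a carboxylic acid or a chain ending in an amine, would move the number beyond the scatter, and what changing the methyl carbamate alone would do.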